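The source may hold more compounds than are shown below. What is called first, only, known or untested is meant among the compounds shown, and "the series" means these compounds.

Two compounds of this series have numbers in a functional assay on 3T3-L1 cells (Mus musculus) for inhibition, with a stated time of 20 min, tested at 20 uM (on this read-out lower numbers stand for less inhibition and higher numbers for more inhibition at the one concentration tested (going by the name of the read-out)), so far. Compound 1 `O=S(=O)(c1ccc(F)cc1)N(Cc1ccccc1)Cc1cccc(F)c1F` gives -81.9% in this assay. Compound 2 `COc1cc(OC)c(Cn2cc(CN(Cc3cn(S(=O)(=O)c4ccc(C)cc4)c4ccccc34)S(=O)(=O)c3ccc(C)cc3)nn2)c(OC)c1` gives -22% in this assay, the higher of the two numbers, and the gap to compound 1 is beyond the scatter. Compound 3 `COc1ccc(Cn2cc(CN(Cc3cn(S(=O)(=O)c4ccc(C)cc4)c4ccccc34)S(=O)(=O)c3ccc(C)cc3)nn2)c(OC)c1` has not yet been measured; it differs from compound 2 by a single change: hydrogen in place of methoxy on an aromatic carbon. Among the measured compounds shown here, nothing among the measured pairs shows what the loss of a methoxy does on this read-out, so the step to compound 3 cannot be read from a precedent. The change is small and the methoxy leaving is one of three on the same ring. For compound 3 the expected step in this assay is a number 2 percentage points higher from compound 2 to compound 3 (within the scatter), no larger than the scatter and without a clear direction. Compound 3 is estimated at -20% in this assay, between -50% and 10%.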

Compound 3, a percentage reported as inhibition, at one concentration (the size of the read-out at that concentration, not a potency): 7.6%
Compound 3: middle estimate off by 27.6 percentage points, on the low side; measured number inside the range.
By their numbers in this assay, from the lowest: compound 1; then compound 2; then compound 3.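

In this assay, going from 2,4,6-trimethoxyphenyl to 2,4-dimethoxyphenyl gives a number 29.6 percentage points higher from compound 2 to compound 3 (beyond the scatter). This aromatic carbon, ortho to a large group and meta to two methoxy groups, therefore registers on this read-out: one methoxy out of three, replaced by hydrogen, moves the number by more than the usual scatter. This is the only single-place step among the compounds shown, so it describes this one change at the one concentration tested, and no measurement shown accounts for its size.

Still open, going by these compounds, is whether the step belongs to this position alone or would also follow the loss of either remaining methoxy. Also open, on these data alone, is what an amine, a carboxylic acid or a longer alkoxy chain on the same aromatic carbon would do in this assay.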